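This account rests on a few compounds, and the source may have more. Where it says the series, first, only, none or still open, it means among the compounds named here.

The three measured compounds share one core and differ only in the ring on the amide-type nitrogen. In an assay on HEK293 cells for agonist activity at transient receptor potential cation channel subfamily M member 8 (Homo sapiens), read by fluorescence and calcium flux, with a stated time of 15 min (a higher number here means that more compound is needed for the effect, a lower number that less compound is needed), compound 1 `Cc1ccc(OCC(=O)N(Cc2cccs2)c2ncco2)cc1` gives 0.3 nM, and compound 2 `Cc1ccc(OCC(=O)N(Cc2cccs2)c2ccn[nH]2)cc1` gives 0.2 nM in this assay; the step of a 1.5-fold lower number from compound 1 to compound 2 (0.18 log units; within the scatter) is within the scatter. Compound 3 `Cc1ccc(OCC(=O)N(Cc2cccs2)c2ncccn2)cc1` gives 3700 nM in this assay, the highest of the three numbers, and both steps leading to it, a 12000-fold higher number from compound 1 to compound 3 (4.09 log units; beyond the scatter) and a 19000-fold higher number from compound 2 to compound 3 (4.27 log units; beyond the scatter), are far beyond the scatter. Compound 4 `Cc1ccc(OCC(=O)N(Cc2cccs2)c2cnccn2)cc1` has not yet been measured. It differs from compound 3 by pyrazin-2-yl in place of pyrimidin-2-yl on an amide-type nitrogen. Among the compounds with values here, no measured step compares two six-membered rings at this position, so the only steps that bear on the change are a 12000-fold higher number from compound 1 to compound 3 (4.09 log units; beyond the scatter) and a 19000-fold higher number from compound 2 to compound 3 (4.27 log units; beyond the scatter), which show that the six-membered pyrimidin-2-yl carries a very large increase relative to the rings of compounds 1 and 2. Compound 4 keeps a six-membered ring with the same atoms, so the account expects it to remain close to compound 3, with the step of a 1.2-fold lower number from compound 3 to compound 4 (0.09 log units; within the scatter) expected to stay within or only modestly beyond the scatter. Compound 4 is therefore estimated to give about 3000 nM in this assay, within a range from 400 nM to 20000 nM.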

Compound 4, half-maximal effective concentration: 1240 nM
Compound 4: middle estimate off by 2.4-fold (0.38 log units), on the high side; the measured number falls inside the stated range.
By their numbers in this assay, from the lowest: compounds 2 and 1 (each within the scatter of the next); then compound 4; then compound 3.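

Swapping one six-membered ring for another with the same atoms does register at this position on the amide-type nitrogen in this assay: the change shows a 3.0-fold lower number from compound 3 to compound 4 (0.47 log units; beyond the scatter), so how the atoms are joined within the ring matters here, which no earlier step could show. That modest step is small beside the steps from the other two rings, a 4100-fold higher number from compound 1 to compound 4 (3.62 log units; beyond the scatter) and a 6200-fold higher number from compound 2 to compound 4 (3.79 log units; beyond the scatter), so the large rise first seen with pyrimidin-2-yl is not confined to that one ring and also holds for pyrazin-2-yl. Nothing available here accounts for the gap between the two six-membered rings or for their distance from 1,3-oxazol-2-yl and 1H-pyrazol-5-yl.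

The compounds shown leave open where a pyridin-2-yl ring or a phenyl ring would fall, and whether a 1,3-thiazol-2-yl ring would stay with compound 1 and compound 2. They also leave open whether the same order of rings would hold if the methyl group on the shared core gave way to a chlorine atom or a methoxy group.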